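Trading a Difluorophenyl Ring for a Methyl Group

The compounds below may be only part of what the source reports. "The series", "measured", "known", "first", "only" and "open" are said of these compounds alone.

Compound 2 `N=C(NCCCc1c[nH]cn1)NC(=O)CC(c1ccc(F)c(F)c1)c1nccs1` is the starting point. Among the measured compounds shown here, in a functional assay on cardiac atrium for agonist activity at histamine H2 receptor (Cavia porcellus) (a lower number here means that less compound is needed, a higher number that more compound is needed for the effect), compound 2 gives 50.1 nM, the lowest of the three numbers measured so far, although compound 1 `N=C(NCCCc1c[nH]cn1)NC(=O)CC(c1ccccc1)c1ccc(F)c(F)c1` with 53.7 nM lies within the scatter, as a 1.1-fold lower number from compound 1 to compound 2 (0.03 log units; within the scatter) shows. Compound 3 `N=C(NCCCc1c[nH]cn1)NC(=O)CC(c1ccc(F)c(F)c1)c1nccn1Cc1ccccc1` gives 398 nM in this assay; the steps of a 7.4-fold higher number from compound 1 to compound 3 (0.87 log units; beyond the scatter) and a 7.9-fold higher number from compound 2 to compound 3 (0.90 log units; beyond the scatter) show that altering one of the two rings on the saturated chain carbon can cost potency. Compound 4 `CC(CC(=O)NC(=N)NCCCc1c[nH]cn1)c1nccs1` carries methyl in place of 3,4-difluorophenyl on a saturated chain carbon bound to an aromatic carbon and a saturated chain carbon. For the measured compounds named here, no measured step removes a ring entirely, so the only guide is that swaps at this carbon ranged from no change to a modest loss. A larger loss is expected here, a 6.0-fold higher number from compound 2 to compound 4 (0.78 log units; beyond the scatter), so compound 4 is estimated at 300 nM (range 80 nM to 1500 nM).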

Compound 4, half-maximal effective concentration: 38.9 nM
The estimate for compound 4 lay 7.7-fold (0.89 log units) above the measured number; the measured number lies below the stated range.
By their numbers in this assay, from the lowest: compounds 4, 2 and 1 (each within the scatter of the next); then compound 3.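

Earlier swaps only exchanged one ring for another at this saturated chain carbon, whereas here the 3,4-difluorophenyl ring goes entirely and a single methyl takes its place. In this assay this gives a 1.3-fold lower number from compound 2 to compound 4 (0.11 log units; within the scatter), so with the 1,3-thiazol-2-yl group kept, a second ring at this carbon is not needed for the effect. Nothing available explains this result. Going by these compounds, how an ethyl or a cyclopropyl group would behave at this carbon remains open. So does whether methyl would be tolerated alongside the 1-benzyl-1H-imidazol-2-yl group of compound 3.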